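Hydroxy in place of trifluoromethyl on the cinnamamide

A few compounds are considered here, and "the series" means these few. Any claim that something is new, unique, unknown or untested is made for them only; others in the source may bear on it.

Of the compounds shown here, three sharing one core have been measured in a functional assay on CHO cells for inhibition of transient receptor potential cation channel subfamily V member 1 (Homo sapiens); on this read-out higher numbers stand for weaker inhibition and lower numbers for stronger inhibition. Compound 1 `Cc1ccc(/C=C/C(=O)Nc2ccc3c(c2)OCCO3)cc1` gives 1100 nM, compound 2 `CC(C)c1ccc(/C=C/C(=O)Nc2ccc3c(c2)OCCO3)cc1` gives 82 nM, and compound 3 `O=C(/C=C/c1ccc(C(F)(F)F)cc1)Nc1ccc2c(c1)OCCO2` gives 100 nM. Compound 3 therefore stands second highest of the three; its nearest neighbour is compound 2, with a 1.2-fold higher number from compound 2 to compound 3 (0.09 log units; within the scatter) between them, and its furthest is compound 1, with an 11-fold lower number from compound 1 to compound 3 (1.04 log units; beyond the scatter) separating them.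

The step now followed leads from compound 3 to compound 4 `O=C(/C=C/c1ccc(O)cc1)Nc1ccc2c(c1)OCCO2`: hydroxy in place of trifluoromethyl on an aromatic carbon. Within the data shown here, no measured step covers this exchange. The two steps that touch this position both start from methyl: a 13-fold lower number from compound 1 to compound 2 (1.13 log units; beyond the scatter) and an 11-fold lower number from compound 1 to compound 3 (1.04 log units; beyond the scatter). Both show that the substituent on this aromatic carbon moves the number by a large amount, and that methyl is the weakest of the three groups examined. Hydroxy has not been tried here, so its effect can only be inferred from the fact that the group at this site matters. On that basis, compound 4 is expected to give a higher number than compound 3, with a 30-fold higher number from compound 3 to compound 4 (1.48 log units; beyond the scatter) as the estimated step, and the estimate for compound 4 is 3000 nM, ranging from 700 nM to 13000 nM.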

Compound 4, half-maximal inhibitory concentration: > 4000 nM
Compound 4: no number, only a limit; the forecaster's own chance of this, stated with the estimate: 15%; at least 1.3-fold (0.12 log units) between middle value and limit.
By their numbers in this assay, from the lowest: compounds 2 and 3 (each within the scatter of the next); then compound 1. At a limit, above all of these: compound 4.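

Compound 4 gives no number in this assay, only a limit: the limit of > 4000 nM in this assay, at which 1 of the 4 values shown sits. The earlier compounds shown here had placed methyl at the high end of the range at this aromatic carbon, but the new result shows that the range reaches further, since hydroxy stands beyond methyl with an at least 3.6-fold higher number from compound 1 to compound 4 (0.56 log units; beyond the scatter). The exchange away from the two better groups is larger still, with an at least 40-fold higher number from compound 3 to compound 4 (1.60 log units; beyond the scatter) and an at least 48-fold higher number from compound 2 to compound 4 (1.68 log units; beyond the scatter), so a small group carrying a hydrogen-bond donor and a hydrogen-bond acceptor is, on this read-out, the poorest choice of the four shown, and isopropyl and trifluoromethyl, which lie within the scatter of each other, both stand well clear of it.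

The compounds shown leave open whether the oxygen or the hydroxy hydrogen goes with this loss, a question that methoxy at the same place would address, and how an amine, a carboxylic acid or chlorine would behave there. As far as these compounds go, since compound 4 rests on a limit, how far it truly lies from the other three also stays open.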